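Hydroxyphenyl isomers: the step to compound 3

The source may hold more compounds than are shown below. What is called first, only, known or untested is meant among the compounds shown, and "the series" means these compounds.

Among the measured compounds shown here, in a functional assay on MDA-MB-231 cells (Homo sapiens) for cytotoxicity, read by ELISA, with a stated time of 2 days (on this read-out higher numbers stand for weaker inhibition and lower numbers for stronger inhibition), compound 1 `Oc1ccccc1-c1cc(-c2ccccc2)nc(-c2ccco2)c1` gives 4600 nM, and compound 2 `Oc1cccc(-c2cc(-c3ccccc3)nc(-c3ccco3)c2)c1` gives 20800 nM, the higher of the two numbers so far. Compound 3 `Oc1ccc(-c2cc(-c3ccccc3)nc(-c3ccco3)c2)cc1` has not yet been measured. Its change from compound 2 is 4-hydroxyphenyl in place of 3-hydroxyphenyl on an aromatic carbon, with the core otherwise the same. For the measured compounds named here, only one measured step bears on this, a 4.5-fold higher number from compound 1 to compound 2 (0.66 log units; beyond the scatter), a modest change that also involves only the hydroxyl position on this phenyl group. Going by the values given here, that step shows that such a move can matter in this assay, but the data hold no 4-hydroxyphenyl compound, so direction remains uncertain. A smaller change is expected, leaning slightly towards a lower number. The expected step is a 1.4-fold lower number from compound 2 to compound 3 (0.14 log units; within the scatter). The estimate for compound 3 is 15000 nM, with an expected range of 5000 nM to 40000 nM.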

Compound 3, half-maximal inhibitory concentration: 1000 nM
Compound 3: middle estimate off by 15-fold (1.18 log units), on the high side; the measured number lies below the stated range.
By their numbers in this assay, from the lowest: compound 3; then compound 1; then compound 2.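

In this assay the hydroxyl position on this phenyl group carries more weight than the first pair suggested, with a 21-fold lower number from compound 2 to compound 3 (1.32 log units; beyond the scatter) as the largest step in the set and with a 4.6-fold lower number from compound 1 to compound 3 (0.66 log units; beyond the scatter) as a second step in the same direction. The position effect does not run as a steady trend around the ring: the 3-hydroxyphenyl compound 2 has the highest number of the three, while the 4-hydroxyphenyl compound 3 has the lowest and the 2-hydroxyphenyl compound 1 falls in the middle. Nothing available explains why this change has so large an effect.

Still open, from the compounds shown here alone, is whether a methoxy group or an amine in place of the hydroxyl of the 4-hydroxyphenyl group would hold the number of compound 3. Going by these compounds, the contributions of the furan-2-yl and phenyl groups also remain unknown, as both stay the same throughout.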